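A few compounds are considered here, and "the series" means these few. Any claim that something is new, unique, unknown or untested is made for them only; others in the source may bear on it.

Measured compounds, with their numbers in an assay on CHO cells for displacement of a labelled ligand from adenosine receptor A3 (Homo sapiens); on this read-out higher numbers stand for weaker inhibition and lower numbers for stronger inhibition:
compound 1 `CCNC(=O)[C@H]1O[C@@H](n2cnc3c(NCc4cccc(I)c4)nc(Cl)nc32)[C@H](O)[C@@H]1O` gives 0.891 nM
compound 2 `O=C(NCC1CC1)[C@H]1O[C@@H](n2cnc3c(NCc4cccc(I)c4)nc(Cl)nc32)[C@H](O)[C@@H]1O` gives 3.63 nM
compound 3 `O=C(NC1CCC1)[C@H]1O[C@@H](n2cnc3c(NCc4cccc(I)c4)nc(Cl)nc32)[C@H](O)[C@@H]1O` gives 18.2 nM

Compound 2 stands second highest of the three numbers in this assay. Its nearest neighbour is compound 1, with a 4.1-fold higher number from compound 1 to compound 2 (0.61 log units; beyond the scatter); its furthest is compound 3, with a 5.0-fold higher number from compound 2 to compound 3 (0.70 log units; beyond the scatter). The remaining measured step, a 20-fold higher number from compound 1 to compound 3 (1.31 log units; beyond the scatter), likewise concerns only the group on the amide-type nitrogen.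

Compound 4 `Cc1ccccc1CNc1nc(Cl)nc2c1ncn2[C@@H]1O[C@H](C(=O)NCC2CC2)[C@@H](O)[C@H]1O` differs from compound 2 at a different place: 2-methylphenyl in place of 3-iodophenyl on a saturated chain carbon bound to a nitrogen on an aromatic ring. Going by the values given here, none of the three measured steps touches the benzyl part of the shared core; every one of them varies the amide-type nitrogen and leaves the 3-iodobenzyl group untouched, so no measured step bears on the change in hand, either in size or in direction. The expectation for compound 4 in this assay therefore rests on no comparison from this set and carries a wide range. With nothing in the set that speaks for the entering 2-methylphenyl group, a step towards a higher number is taken as the more likely outcome, and an 8.3-fold higher number from compound 2 to compound 4 (0.92 log units; beyond the scatter) is expected. Compound 4 is estimated at 30 nM, within 6 nM to 150 nM.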

Compound 4, inhibition constant: 29.5 nM
Compound 4: the middle estimate sits 1.0-fold (0.01 log units) above what was measured, within the range that was stated.
By their numbers in this assay, from the lowest: compound 1; then compound 2; then compounds 3 and 4 (each within the scatter of the next).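

Going by these compounds alone, the change from 3-iodophenyl to 2-methylphenyl on a saturated chain carbon bound to a nitrogen on an aromatic ring gives, in this assay, an 8.1-fold higher number from compound 2 to compound 4 (0.91 log units; beyond the scatter) and is the first measured change at this place, with the cyclopropylmethyl group on the amide-type nitrogen held constant. The number at this place therefore responds to the aryl group even though both groups have the same count of heavy atoms, and this step is graded modest, as are a 4.1-fold higher number from compound 1 to compound 2 (0.61 log units; beyond the scatter) and a 5.0-fold higher number from compound 2 to compound 3 (0.70 log units; beyond the scatter) on the amide-type nitrogen. No available evidence bears on what lies behind the step at this place.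

Within the data shown here, the single step replaces iodine with methyl and also changes the name position from 3 to 2, so the two parts of the change cannot be separated; 3-methylphenyl, 2-iodophenyl or unsubstituted phenyl at the same place would divide them. From the compounds shown here alone, it also remains open whether the step carries over to other groups on the amide-type nitrogen, such as the ethyl group of compound 1 or the cyclobutyl group of compound 3.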